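A few compounds are considered here, and "the series" means these few. Any claim that something is new, unique, unknown or untested is made for them only; others in the source may bear on it.

Compound 1 `CCCC[C@@H]1CC[C@@H](c2cc(C)no2)N1C` serves as the measured reference point in an assay on cell membranes for displacement of a labelled ligand from Neuronal acetylcholine receptor; alpha4/beta2 (Rattus norvegicus) (on this read-out higher numbers stand for weaker inhibition and lower numbers for stronger inhibition), where compound 1 gives 1020 nM. Compound 2 `Cc1cc([C@@H]2CC[C@H](c3ccccc3)N2C)on1` has also been tested in this assay, and there compound 2 gives only a limit of the assay, > 10000 nM. Compound 2 therefore stands at the edge of what the assay reports rather than at a number, a situation described by the limit of > 10000 nM in this assay, at which 1 of the 2 values shown sits. Compound 3 `Cc1cc([C@@H]2CC[C@@H](c3ccccc3)N2C)on1` has not yet been measured in this assay. The change from compound 2 to compound 3 is the two compounds have the same atoms and bonds and differ only in configuration as drawn: 1 of 2 stereo elements differ; a stereocentre at a saturated ring carbon is drawn R in compound 2 and S in compound 3; the two compounds have the same atoms and bonds and differ only in configuration as drawn. Going by the values given here, no measured step between any two compounds is available, so the size of this step can only be anticipated. A step of an at least 2.5-fold lower number from compound 2 to compound 3 (0.39 log units; beyond the scatter) is expected, pointing toward stronger inhibition, though the starting limit leaves its true size uncertain. Compound 3 is estimated to give 4000 nM in this assay. For compound 3 the expected range runs from 1000 nM to 20000 nM.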

Compound 3, inhibition constant: 8000 nM
For compound 3 the middle estimate is 2.0-fold (0.30 log units) below the measured one; the measured number falls inside the stated range.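

The stereocentre at a saturated ring carbon now has a reading in this assay, an at least 1.2-fold lower number from compound 2 to compound 3 (0.09 log units; that floor lies within the scatter), and any difference between these two compounds can be traced to that centre alone: the fact that compounds 2 and 3 differ only in the configuration as drawn. The true size of this difference remains unsettled and its floor does not clear the scatter, because compound 2 gives no number: the limit of > 10000 nM in this assay, at which 1 of the 3 values shown sits. The group on a saturated ring carbon now has a measured step, a 7.8-fold higher number from compound 1 to compound 3 (0.89 log units; beyond the scatter), which shows that phenyl in place of butyl goes with weaker inhibition, beyond the scatter.

The compounds shown leave open whether changing the same stereocentre would matter in the same way with butyl as with phenyl. They also leave open what a benzyl group or a longer chain such as hexyl would give on that carbon in this assay.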